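The source may report more compounds than this note shows. Statements on the series, on what has been measured and on what is new or still open speak of the compounds shown alone.

Measured in an in vitro ADME assay on microsomes from liver (Mus musculus) for pharmacokinetics, read by LC-MS, with a stated time of 60 min, tested at 5 uM; a higher number here means faster removal of the compound, a lower number slower removal:
Compound 1 `COc1ccc(C(N)=O)cc1/C=C/c1ccc(Cl)cc1` gives 110 mL.min-1.g-1
Compound 2 `COc1ccc(C(N)=O)cc1/C=C\c1ccc(Cl)cc1` gives 544 mL.min-1.g-1
Compound 3 `CNC(=O)c1ccc(OC)c(/C=C/c2ccc(Cl)cc2)c1` gives 331 mL.min-1.g-1

Compound 3, at 331 mL.min-1.g-1, lies within the scatter of compound 2 and beyond the scatter above compound 1. Compound 4 `COc1ccc(C(=O)NCCO)cc1/C=C/c1ccc(Cl)cc1` differs from compound 3 by hydroxymethyl in place of hydrogen on a saturated chain carbon bound to an amide-type nitrogen, so that methyl becomes 2-hydroxyethyl on the amide-type nitrogen. Among the measured compounds shown here, only one measured step concerns that nitrogen: a 3.0-fold higher number from compound 1 to compound 3 (0.48 log units; beyond the scatter), with methyl in place of hydrogen. The other, a 4.9-fold higher number from compound 1 to compound 2 (0.69 log units; beyond the scatter), reflects the fact that compounds 1 and 2 differ only in the configuration as drawn and does not bear on this change. The step to compound 3 shows that a change on this nitrogen can move the number in this assay, but it sets no direction for lengthening the methyl to 2-hydroxyethyl. No step beyond the scatter is therefore expected. The expected step is a 1.1-fold lower number from compound 3 to compound 4 (0.04 log units; within the scatter). Compound 4 is estimated at 300 mL.min-1.g-1, with an expected range from 130 mL.min-1.g-1 to 700 mL.min-1.g-1.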

Compound 4, intrinsic clearance in microsomes: 73 mL.min-1.g-1
Estimate against measurement, compound 4: 4.1-fold (0.61 log units) above; the whole stated range lies above it.
By their numbers in this assay, from the lowest: compounds 4 and 1 (each within the scatter of the next); then compounds 3 and 2 (each within the scatter of the next).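

In this assay the outcome on the amide-type nitrogen turns out to depend on what is attached there: methyl to 2-hydroxyethyl gives a 4.5-fold lower number from compound 3 to compound 4 (0.66 log units; beyond the scatter) whereas the earlier step on this nitrogen, methyl in place of hydrogen, gave a 3.0-fold higher number from compound 1 to compound 3 (0.48 log units; beyond the scatter) and so ran the other way. Hydroxymethyl on the saturated chain carbon bound to that nitrogen thus undoes the step seen with methyl. With 2-hydroxyethyl in place of hydrogen the comparison reads a 1.5-fold lower number from compound 1 to compound 4 (0.18 log units; within the scatter) so a substituent on this nitrogen need not move the number beyond the scatter.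

As far as these compounds go, whether the step belongs to the hydroxyl or to the chain length stays open, and an ethyl or a 2-methoxyethyl group on the same nitrogen would separate the two. Nothing given here accounts for the step.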